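Lengthening the Alkyl Chain on the Shared Core

A few compounds are considered here, and "the series" means these few. Any claim that something is new, unique, unknown or untested is made for them only; others in the source may bear on it.

Measured so far:
Compound 1, `CCCCCCCc1cc2cn(COCCO)c(=O)nc2o1`, gives 400000 nM in a functional assay on HEL cells (Homo sapiens), read by microscopy; a lower number here means that less compound is tolerated, a higher number that more compound is tolerated.
Compound 2, `CCCCCC#Cc1cc2cn(COCCO)c(=O)nc2o1`, gives >= 100000 nM in this assay, which is a limit of the assay rather than a number.

Among the compounds with values here, compound 1 therefore holds the only number in this assay, and the step that the limit leaves unreadable from compound 1 to compound 2 cannot be read, as the limit of >= 100000 nM in this assay, at which 1 of the 2 values shown sits, shows. Compound 3, `CCCCCCCCc1cc2cn(COCCO)c(=O)nc2o1`, differs from compound 1 by methyl in place of hydrogen on a saturated chain carbon, seven bonds along the chain from an aromatic carbon. No readable step bears on such a change, so the step of no change at the digits printed from compound 1 to compound 3 (within the scatter) is expected to stay within the scatter. Compound 3 is estimated at 400000 nM, between 150000 nM and 1000000 nM.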

Compound 3, minimum cytotoxic concentration: >= 80000 nM
Compound 3: no number, only a limit; the forecaster's own chance of this, stated with the estimate: 20%; the middle value does not contradict the limit.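

Within the data shown here, compound 3, like compound 2, gives only a limit of the assay, so no step from compound 1 to either can be read. The compounds shown leave open whether changing the chain on the shared core shifts the concentration tolerated in this assay.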